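The compounds below may be only part of what the source reports. "The series", "measured", "known", "first", "only" and "open" are said of these compounds alone.

Measured in an ADME assay on microsomes from liver (Homo sapiens) for pharmacokinetics, read by LC-MS, with a stated time of 60 min, tested at 1 uM; on this read-out lower numbers stand for slow clearance and higher numbers for fast clearance:
- compound 1 `O=C(NCc1ccc(S(=O)(=O)c2ccccc2)cc1)N1Cc2ccncc2C1`: 7.5 mL/min/kg
- compound 2 `O=C(NCc1ccc(S(=O)(=O)c2cccc(C(F)(F)F)c2)cc1)N1Cc2ccncc2C1`: 14 mL/min/kg
- compound 3 `O=C(NCc1ccc(S(=O)(=O)N2CCC(O)CC2)cc1)N1Cc2ccncc2C1`: 6 mL/min/kg

Compound 3, at 6 mL/min/kg, holds the lowest of the three numbers, though it is separated clearly only from compound 2. The measured steps are a 1.3-fold lower number from compound 1 to compound 3 (0.10 log units; within the scatter) and a 2.3-fold lower number from compound 2 to compound 3 (0.37 log units; beyond the scatter). Both exchange an aromatic group on the sulfonyl sulfur for 4-hydroxypiperidin-1-yl. The step of a 1.9-fold higher number from compound 1 to compound 2 (0.27 log units; within the scatter) shows the range seen so far among the aromatic groups.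

Next is compound 4 `O=C(NCc1ccc(S(=O)(=O)N2CC3(CCOCC3)C2)cc1)N1Cc2ccncc2C1`, which carries a change at that same sulfonyl sulfur: a group of 9 heavy atoms (7 carbon, 1 nitrogen, 1 oxygen; one four-membered non-aromatic ring with 1 hetero atom, one six-membered non-aromatic ring with 1 hetero atom) in place of a group of 7 heavy atoms (5 carbon, 1 nitrogen, 1 oxygen; one six-membered non-aromatic ring with 1 hetero atom), on a sulfonyl sulfur. Going by the values given here, no measured step exchanges one non-aromatic group for another, so the evidence is indirect. Only a 2.3-fold lower number from compound 2 to compound 3 (0.37 log units; beyond the scatter) exceeds the scatter, and that step is modest. A small change is therefore expected in this assay, with no step beyond the scatter. The expected step, a slight rise at most, is a 1.3-fold higher number from compound 3 to compound 4 (0.12 log units; within the scatter). For compound 4 the estimated value is 8 mL/min/kg, with an expected range of 4.5 mL/min/kg to 15 mL/min/kg.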

Compound 4, clearance: 13 mL/min/kg
For compound 4 the middle estimate is 1.6-fold (0.21 log units) below the measured one; measured number inside the range.
By their numbers in this assay, from the lowest: compounds 3, 1, 4 and 2 (each within the scatter of the next, the first and the last beyond it).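

In this assay, the sulfonyl sulfur now has a step between two non-aromatic groups, a 2.2-fold higher number from compound 3 to compound 4 (0.34 log units; beyond the scatter), with the entering group of 9 heavy atoms replacing 4-hydroxypiperidin-1-yl. A non-aromatic group on this sulfur therefore does not by itself hold the number at the level of compound 3, as a 1.1-fold lower number from compound 2 to compound 4 (0.03 log units; within the scatter) and a 1.7-fold higher number from compound 1 to compound 4 (0.24 log units; within the scatter) place compound 4 within the scatter of both aromatic comparators. No measurement shown gives a reason for the step.

The compounds shown do not separate the hydroxyl of compound 3 from the rest of the group as the part that goes with the step. Also open, from the compounds shown here alone, is how a morpholin-4-yl or 4-aminopiperidin-1-yl group would read on this sulfur.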